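Lengthening the Amide Chain: Compound 2 to Compound 4

This account rests on a few compounds, and the source may have more. Where it says the series, first, only, none or still open, it means among the compounds named here.

Measured in a functional assay on HT-1080 cells (Homo sapiens) for antiproliferative activity, read by sulforhodamine B assay, with a stated time of 48 h; a higher number here means a weaker inhibitor, a lower number a stronger inhibitor:
Compound 1, `CCC(=O)Nc1cccc(S(=O)(=O)Oc2ccccc2C(C)C)c1`, gives 12000 nM.
Compound 2, `CC(=O)Nc1ccc(S(=O)(=O)Oc2ccccc2C(C)C)cc1`, gives 12000 nM.
Compound 3, `CC(=O)Nc1ccc(S(=O)(=O)Oc2ccccc2I)cc1`, gives 17000 nM.

Compound 2 stands level with compound 1, the two together giving the lowest of the three numbers, and the step of a 1.4-fold higher number from compound 2 to compound 3 (0.15 log units; within the scatter) stays within the scatter. Compound 4, `CCC(=O)Nc1ccc(S(=O)(=O)Oc2ccccc2C(C)C)cc1`, differs from compound 2 by methyl in place of hydrogen on a saturated chain carbon bound to a carbonyl carbon. Among the measured compounds shown here, no measured step isolates this change. The nearest evidence is compound 1, which already carries propanoylamino and in this assay gives 12000 nM, the same digits as compound 2. Compound 4 is therefore expected to show no shift beyond the scatter, no change at the digits printed from compound 2 to compound 4 (within the scatter). The estimate for compound 4 is 12000 nM, within 6000 nM to 24000 nM.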

Compound 4, half-maximal inhibitory concentration: 2100 nM
Compound 4: middle estimate off by 5.7-fold (0.76 log units), on the high side, outside the stated range (below it).
By their numbers in this assay, from the lowest: compound 4; then compounds 1, 2 and 3 (each within the scatter of the next).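

Adding one methyl to the saturated chain carbon bound to the carbonyl carbon, which turns acetamido into propanoylamino, gives a 5.7-fold lower number from compound 2 to compound 4 (0.76 log units; beyond the scatter) and so shows that this small change can move the number. Compound 1 carries the same propanoylamino at a different place on the shared core and gives 12000 nM in this comparison, so the group alone does not set the number. Nothing available explains why this step occurs.

As far as these compounds go, whether a longer chain, such as butanoyl, would lower the number further remains open. So does whether a branched isobutyryl group or a benzoyl group would be tolerated here.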